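Furanyl ketone analogue in the trimethoxyphenyl-triazolothiadiazine series

The source may report more compounds than this note shows. Statements on the series, on what has been measured and on what is new or still open speak of the compounds shown alone.

Measured so far in a functional assay on PC-3 cells (Homo sapiens) for cytotoxicity, read by MTT assay, with a stated time of 48 h; a higher number here means a weaker inhibitor, a lower number a stronger inhibitor:
compound 1 `COc1cc(C(=O)C2Sc3nnc(-c4cc(OC)c(OC)c(OC)c4)n3NC2c2ccco2)cc(OC)c1OC` 52200 nM
compound 2 `COc1cc(-c2nnc3n2NC(c2ccco2)C(C(=O)c2ccccc2)S3)cc(OC)c1OC` 64300 nM
compound 3 `COc1cc(-c2nnc3n2NC(c2ccco2)C(C(=O)c2cccc(Br)c2)S3)cc(OC)c1OC` 63900 nM

The three numbers lie close together. Compound 1 sits at the low end of them, but the steps of a 1.2-fold higher number from compound 1 to compound 2 (0.09 log units; within the scatter) and a 1.2-fold higher number from compound 1 to compound 3 (0.09 log units; within the scatter) both fall inside the scatter, and a 1.0-fold lower number from compound 2 to compound 3 (0.00 log units; within the scatter) does likewise, so no ordering among the three can be claimed.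

Compound 4 `COc1cc(-c2nnc3n2NC(c2ccco2)C(C(=O)c2ccco2)S3)cc(OC)c1OC` is not yet measured. It differs from compound 1 by furan-2-yl in place of 3,4,5-trimethoxyphenyl on a carbonyl carbon. Among the compounds with values here, the steps that bear on it are the two other exchanges at the same carbonyl carbon, from compound 1 to compound 2 and from compound 1 to compound 3, neither of which moved the number beyond the scatter. A step of about the same size is therefore expected in this assay, with no clear direction: compound 4 is estimated at 56000 nM, range 26000 nM to 120000 nM, which amounts to an expected 1.1-fold higher number from compound 1 to compound 4 (0.03 log units; within the scatter).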

Compound 4, half-maximal inhibitory concentration: 58300 nM
Estimate against measurement, compound 4: 1.0-fold (0.02 log units) below; low and high end bracket the measured number.
By their numbers in this assay, from the lowest: compounds 1, 4, 3 and 2 (each within the scatter of the next).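

In this assay, the carbonyl carbon now carries a five-membered aromatic ring with a hetero atom, and furan-2-yl in place of 3,4,5-trimethoxyphenyl gives a 1.1-fold higher number from compound 1 to compound 4 (0.05 log units; within the scatter). The same holds against the other two ketones, with a 1.1-fold lower number from compound 3 to compound 4 (0.04 log units; within the scatter) and a 1.1-fold lower number from compound 2 to compound 4 (0.04 log units; within the scatter), so among these four compounds neither ring type nor heavy-atom count separates the numbers. No measurement available here accounts for this flat result.

From the compounds shown here alone, whether a non-aromatic group on this carbonyl carbon, such as an amine, a carboxylic acid or a longer alkyl chain, would give a step beyond the scatter remains open.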